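From phenyl to 4-chlorophenyl in this series

The source may hold more compounds than are shown below. What is called first, only, known or untested is meant among the compounds shown, and "the series" means these compounds.

Going by the values given here, in an ADME assay on L6 cells (Rattus norvegicus) for cytotoxicity (a lower number here means a stronger inhibitor, a higher number a weaker inhibitor), compound 2 (`CC1CCc2ccccc2N1S(=O)(=O)c1ccccc1`) gives 70000 nM, the higher of the two numbers measured so far. Compound 1 (`CC1CCc2ccccc2N1S(=O)(=O)c1ccc(Br)cc1`) gives 7360 nM. The next structure, compound 3 (`CC1CCc2ccccc2N1S(=O)(=O)c1ccc(Cl)cc1`), has chloro in place of hydrogen on an aromatic carbon of compound 2, para to a large group: chloro in place of hydrogen on an aromatic carbon.

Among the compounds with values here, only one measured step bears on this change: a 9.5-fold higher number from compound 1 to compound 2 (0.98 log units; beyond the scatter), with hydrogen in place of bromo on an aromatic carbon. Read backwards, it links a halogen on that ring to the lower number, so chloro is expected to move this assay in the same direction. Chloro is not bromo, however, and one step cannot show how far the result carries over from one group to the other. A somewhat smaller change than the measured one is therefore assumed, though still beyond the scatter. The expected size is a 4.7-fold lower number from compound 2 to compound 3 (0.67 log units; beyond the scatter), towards a lower number. For compound 3 the estimate is 15000 nM, with an expected range of 6000 nM to 40000 nM.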

Compound 3, half-maximal inhibitory concentration: 20500 nM
The estimate for compound 3 lay 1.4-fold (0.14 log units) below the measured number, and the stated range covers the measured number.
By their numbers in this assay, from the lowest: compound 1; then compound 3; then compound 2.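

Chloro in place of hydrogen at this position, para to a large group, gives a 3.4-fold lower number from compound 2 to compound 3 (0.53 log units; beyond the scatter) in this assay, so the lower number no longer rests on bromo alone but is seen with a second halogen. The two halogens are still not equivalent here, since a 2.8-fold higher number from compound 1 to compound 3 (0.44 log units; beyond the scatter) places chloro clearly short of bromo and gives the order bromo, chloro, hydrogen from the lowest number to the highest, with no compound shown going against it. No measurement at hand explains this order or the size of either step.

The three compounds leave open whether the order continues with fluoro or iodo, and whether a non-halogen such as methyl, methoxy, an amine or a carboxylic acid at the same place would also lower the number. On these data alone, it also remains open whether the steps seen here on the phenyl group would hold with another substituent on the core, as every comparison so far shares the same core and changes only this one position.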